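The compounds below may be only part of what the source reports. "The series", "measured", "known", "first", "only" and "open" are said of these compounds alone.

Working notes on the series. The series is followed in a functional assay on MV4-11 cells (Homo sapiens) for inhibition, read by luminescence and CellTiter-Glo, with a stated time of 72 h; on this read-out lower numbers stand for stronger inhibition and higher numbers for weaker inhibition. Compound 1 `CCN1CCN(c2c(C(C)=O)c(=O)oc3cc(Nc4ncc(F)c(-c5ccc(F)cc5OC)n4)ccc23)CC1` gives 550 nM in this assay. Among the compounds with values here, compound 2 `COc1ccccc1-c1ccnc(Nc2ccc3c(C)c(C(C)=O)c(=O)oc3c2)n1` gives 10200 nM in this assay, the highest of the two numbers so far; compound 1 sits at a lower number, and the gap between the two lies beyond the usual scatter. Within the data shown here, the two compounds differ in more than one place, so no single step separates them, and the numbers are taken only as what they show.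

Compound 3 `CC(=O)c1c(C)c2ccc(Nc3nccc(-c4cccnc4)n3)cc2oc1=O` has not yet been measured in this assay. Against compound 2 it carries one change, (pyridin-3-yl in place of 2-methoxyphenyl on an aromatic carbon), with the remainder of the shared core kept as in compound 2. Among the measured compounds shown here, no step between measured compounds bears on this change, so there is no measured precedent for it. The expectation is that the step of a 1.2-fold higher number from compound 2 to compound 3 (0.07 log units; within the scatter) stays within the scatter or shifts only modestly, in either direction. On that basis compound 3 is estimated at 12000 nM in this assay, with a range from 3500 nM to 40000 nM.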

Compound 3, half-maximal inhibitory concentration: 12900 nM
Compound 3: middle estimate off by 1.1-fold (0.03 log units), on the low side; low and high end bracket the measured number.
By their numbers in this assay, from the lowest: compound 1; then compounds 2 and 3 (each within the scatter of the next).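

In this assay, within the data shown here, the exchange of 2-methoxyphenyl for pyridin-3-yl on this aromatic carbon gives a 1.3-fold higher number from compound 2 to compound 3 (0.10 log units; within the scatter) and provides the first measured step at this position. Although a six-membered aromatic ring of carbon only gives way to one with 1 hetero atom, and 8 heavy atoms give way to 6, the two compounds cannot be told apart on this read-out, so this pair gives no sign that the position responds to this particular change. The finding rests on a single pair on the shared core of compound 2, and no measurement at hand offers an explanation for it.

The compounds shown leave open how a group of a different kind at this position would read, such as a saturated amine like morpholine, a carboxylic acid or a longer alkyl chain. Among these compounds, also open is whether the same exchange of 2-methoxyphenyl for pyridin-3-yl would read the same way on the core of compound 1, since no single step yet links that compound to the other two.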